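The source may report more compounds than this note shows. Statements on the series, on what has been measured and on what is new or still open speak of the compounds shown alone.

Measured in an assay on microsomes from intestine for inhibition of acyl-CoA:cholesterol acyltransferase (Oryctolagus cuniculus); a higher number here means a weaker inhibitor, a lower number a stronger inhibitor:
compound 1 `CCCCCCCCCCCCCCCCN1NN=C(NC(=O)Nc2c(C(C)C)cccc2C(C)C)N1` gives 57 nM
compound 2 `CCCCCCCCCCCCCSc1nnc(NC(=O)Nc2c(C(C)C)cccc2C(C)C)n1C(C)=O` gives 680 nM
compound 3 `CCCCCCCCCCCCCc1cc(NC(=O)Nc2c(C(C)C)cccc2C(C)C)on1` gives 13 nM

Among these three, compound 3 stands lowest in this assay, and so is the strongest inhibitor of the set: compound 1 sits clearly higher, and compound 2 higher still, both gaps beyond the usual scatter. All three share the same urea attached to the same aryl group; they differ in the heterocycle and in the long chain that hangs from it.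

Compound 4 `CCCCCCCCCCc1cc(NC(=O)Nc2c(C(C)C)cccc2C(C)C)on1` keeps the core of compound 3 and changes only the chain: hydrogen in place of propyl on a saturated chain carbon, ten or more bonds along the chain from an aromatic carbon. Among the compounds with values here, no measured pair shows the effect of shortening this chain, so the expectation rests on compound 3 alone and is loosely held. A modest rise in this assay is expected, that is, a step from compound 3 to compound 4 of a 2.7-fold higher number from compound 3 to compound 4 (0.43 log units; beyond the scatter), with a value for compound 4 estimated at 35 nM, within a range from 10 nM to 120 nM.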

Compound 4, half-maximal inhibitory concentration: 29 nM
For compound 4 the middle estimate is 1.2-fold (0.08 log units) above the measured one; the measured number falls inside the stated range.
By their numbers in this assay, from the lowest: compound 3; then compounds 4 and 1 (each within the scatter of the next); then compound 2.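

Within the data shown here, compound 3 and compound 4 form the only pair here that differs in the chain alone, so the effect of that chain can now be read directly. In this assay, hydrogen in place of propyl gives a 2.2-fold higher number from compound 3 to compound 4 (0.35 log units; beyond the scatter) and so weakens inhibition modestly, though the shorter chain still leaves compound 4 at 29 nM and among the stronger inhibitors shown. No measurement here explains this step. On these data alone, whether a longer chain would strengthen inhibition remains open, as does the effect of ending the chain in an amine or a carboxylic acid.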